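Tert-butyl in place of methyl on the aryl triazole

The source may hold more compounds than are shown below. What is called first, only, known or untested is meant among the compounds shown, and "the series" means these compounds.

Compound 1, `O=C1O/C(=C\Cn2cc(C3=CCCCC3)nn2)C(OCc2ccccc2)=C1OCc1ccccc1`, in a functional assay on U-937 cells (Homo sapiens) for antiproliferative activity, read by MTT assay, with a stated time of 24 h (a higher number here means a weaker inhibitor, a lower number a stronger inhibitor), gives > 100000 nM, which is a limit of the assay and not a number.
Compound 2, `Cc1ccc(-c2cn(CCC3(O)NC(=O)C(OCc4ccccc4)=C3OCc3ccccc3)nn2)cc1`, in this assay gives 54000 nM.

Compound 2 thus stands as the only numeric result of the two; the other entry is the limit, (the limit of > 100000 nM in this assay, at which 1 of the 2 values shown sits). For the measured compounds named here, no step between two measured compounds that differ in a single place is available, so the pair of compound 1 and compound 2 says no more than what the two values show. Compound 3, `CC(C)(C)c1ccc(-c2cn(CCC3(O)NC(=O)C(OCc4ccccc4)=C3OCc3ccccc3)nn2)cc1`, is still to be measured and differs from compound 2 by tert-butyl in place of methyl on an aromatic carbon. Since nothing measured speaks to a change of this kind, the step from compound 2 to compound 3 in this assay is expected to be small, within the usual scatter or a modest move toward stronger inhibition, and the estimate sets it at a 1.4-fold lower number from compound 2 to compound 3 (0.13 log units; within the scatter). Compound 3 is therefore expected to give 40000 nM, with an estimated range from 15000 nM to 120000 nM.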

Compound 3, half-maximal inhibitory concentration: 56500 nM
The estimate for compound 3 lay 1.4-fold (0.15 log units) below the measured number; the measured number falls inside the stated range.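

For the compounds shown here, with compound 3, a step between two compounds differing in one place can be read for the first time: in this assay, tert-butyl in place of methyl on an aromatic carbon, para to a large group, gives a 1.0-fold higher number from compound 2 to compound 3 (0.02 log units; within the scatter) and so leaves the number within the scatter. At this position on the six-membered aromatic ring, going from 4-methylphenyl to 4-(tert-butyl)phenyl, and so from a group of 1 heavy atom to one of 4 heavy atoms, brings no readable change in antiproliferative activity on these cells. Nothing measured in this set offers an explanation for this flat step.

Only these two alkyl groups are shown at this position, so what an amine, a carboxylic acid or a methoxy group would do there remains open. Going by these compounds alone, compound 1 differs from compound 2 and compound 3 in more than one place, so no step involving compound 1 can be read, and the separate contributions of its cyclohexenyl group and its core remain unresolved.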